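The source may report more compounds than this note shows. Statements on the series, on what has been measured and on what is new or still open speak of the compounds shown alone.

Of the compounds shown here, three have been tested in a functional assay on HL-60 cells (Homo sapiens) for cytotoxicity, read by XTT assay, with a stated time of 72 h; a higher number here means a weaker inhibitor, a lower number a stronger inhibitor. Compound 1 (`COc1ccc(C(=O)c2cc(OC)c(OC)c(OC)c2)cc1[N+](=O)[O-]`) gives 1800 nM, compound 2 (`COc1ccc(Cc2ccc(OC)c(OC)c2OC)cc1N`) gives 230 nM, and compound 3 (`COc1ccc(Cc2cc(OC)c(OC)c(OC)c2)cc1N`) gives 29 nM, the lowest number of the three, with both gaps beyond the scatter. Compound 4 (`COc1ccc(Cc2cc(OC)c(OC)c(OC)c2)cc1[N+](=O)[O-]`) has not yet been measured. It matches compound 3 except at one place: nitro in place of amino on an aromatic carbon. Within the data shown here, no measured pair shows this swap alone. Among the measured compounds shown here, the only hint is compound 1, which carries nitro and gives 1800 nM, though it also differs from compound 3 elsewhere. A weakening beyond the scatter is therefore expected in this assay, estimated as a 10-fold higher number from compound 3 to compound 4 (1.01 log units; beyond the scatter). For compound 4 the estimated value is 300 nM, with an expected range from 70 nM to 1500 nM.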

Compound 4, half-maximal inhibitory concentration: 32 nM
Compound 4: the middle estimate sits 9.4-fold (0.97 log units) above what was measured, outside the stated range (below it).
By their numbers in this assay, from the lowest: compounds 3 and 4 (each within the scatter of the next); then compound 2; then compound 1.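

In this assay, nitro in place of amino on this aromatic carbon, ortho to a methoxy group, gives a 1.1-fold higher number from compound 3 to compound 4 (0.04 log units; within the scatter) and thus no readable change. The swap removes the amino group's hydrogen-bond donor and adds heavy atoms, so on this core the amino group is not needed for a low number. Compound 1 at 1800 nM also carries nitro, so that group alone does not set its number.

Going by these compounds, whether a hydroxyl group or a plain hydrogen here would hold the number stays open. Nothing available explains why amino and nitro read alike.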